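A few compounds are considered here, and "the series" means these few. Any claim that something is new, unique, unknown or untested is made for them only; others in the source may bear on it.

Among the compounds with values here, compound 2 `O=C1/C(=C/c2ccccc2)CCC/C1=C\c1cccc([N+](=O)[O-])c1` is one of three compounds measured in a physicochemical assay for lipophilicity (on this read-out higher numbers stand for higher lipophilicity and lower numbers for lower lipophilicity), in which compound 2 gives 5.06. In this assay compound 1 `COc1cc(/C=C2\CCC/C(=C\c3ccccc3[N+](=O)[O-])C2=O)cc(OC)c1OC` gives 4.86 and compound 3 `COc1ccc(/C=C2\CCC/C(=C\c3ccccc3[N+](=O)[O-])C2=O)cc1` gives 4.86; both of these numbers lie within the usual scatter of the number for compound 2, so the three cannot be told apart with confidence. Compound 4 `COc1ccc(/C=C2\CCC/C(=C\c3cccc([N+](=O)[O-])c3)C2=O)cc1` has not yet been measured. It differs from compound 2 in one place: methoxy in place of hydrogen on an aromatic carbon. Within the data shown here, no measured pair shows this change by itself, so nothing beyond the scatter is expected from it. The expected step is a number 0.06 log units lower from compound 2 to compound 4 (within the scatter), within the scatter in either direction. Compound 4 is therefore estimated at 5, in a range from 4.6 to 5.4.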

Compound 4, partition coefficient: 5.06
The estimate for compound 4 lay 0.06 log units below the measured number; measured number inside the range.
By their numbers in this assay, from the lowest: compounds 1, 3, 2 and 4 (each within the scatter of the next).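

In this assay, within the data shown here, phenyl to 4-methoxyphenyl gives no change at the digits printed from compound 2 to compound 4 (within the scatter) and is the first step in which this change stands alone, as no earlier pair differed in one place. It shows that, at this aromatic carbon para to a large group, methoxy in place of hydrogen leaves the read-out without any change that can be told from the scatter. Nothing measured here speaks to why this is so. Going by these compounds, whether an amine or a carboxylic acid at this same place would shift the number stays open. So does whether methoxy would read alike on the aromatic ring that carries the nitro group.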